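From tert-butyl to methyl on the chain carbon

The source may hold more compounds than are shown below. What is called first, only, known or untested is meant among the compounds shown, and "the series" means these compounds.

Measured so far in a functional assay on SW1573 cells (Homo sapiens) for antiproliferative activity, read by sulforhodamine B assay, with a stated time of 48 h (on this read-out higher numbers stand for weaker inhibition of growth and lower numbers for stronger inhibition of growth), for these compounds:
- compound 1 `CCCCCC(C#CC(=O)OC)O/C=C/C(=O)OC` gives 1700 nM
- compound 2 `CCC(C#CC(=O)OC)O/C=C/C(=O)OC` gives 540 nM
- compound 3 `COC(=O)C#CC(O/C=C/C(=O)OC)C(C)(C)C` gives 3000 nM

Compound 3 shares the weak end of this small set with compound 1, as the measurements give a 1.8-fold higher number from compound 1 to compound 3 (0.25 log units; within the scatter) here, and compound 2 lies lower than both. Compound 4 `COC(=O)C#CC(C)O/C=C/C(=O)OC` has not been measured yet. It differs from compound 3 in one place, with methyl in place of tert-butyl on a saturated chain carbon bound to an oxygen on an unsaturated carbon and a triple-bonded carbon as the counted change.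

For the measured compounds named here, two measured steps bear on this. The closest is a 5.6-fold higher number from compound 2 to compound 3 (0.74 log units; beyond the scatter) at the same carbon, with ethyl where compound 4 has methyl. Also relevant is a 3.1-fold lower number from compound 1 to compound 2 (0.50 log units; beyond the scatter) in which the chain gets shorter and the number falls. Going by the values given here, no compound with methyl at that carbon has been measured, so this guide remains indirect. The expected step in this assay is therefore a modest drop beyond the scatter, estimated as a 6.0-fold lower number from compound 3 to compound 4 (0.78 log units; beyond the scatter) overall. Compound 4 is estimated at 500 nM with 200 nM to 1300 nM as the expected range.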

Compound 4, concentration for 50% growth inhibition: 1700 nM
The estimate for compound 4 lay 3.4-fold (0.53 log units) below the measured number, outside the stated range (above it).
By their numbers in this assay, from the lowest: compound 2; then compounds 1, 4 and 3 (each within the scatter of the next).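

In this assay, methyl in place of tert-butyl on the saturated chain carbon leaves the two compounds within the usual scatter (a 1.8-fold lower number from compound 3 to compound 4 (0.25 log units; within the scatter)), so this large cut in the size of the group does not clearly shift growth inhibition. The fall in the number seen on going from pentyl to ethyl does not carry on to methyl: the ethyl compound and the methyl compound lie clearly apart (a 3.1-fold higher number from compound 2 to compound 4 (0.50 log units; beyond the scatter)), while the methyl compound matches the pentyl compound (no change at the digits printed from compound 1 to compound 4 (within the scatter)). Shortening the chain therefore does not steadily strengthen growth inhibition, and compound 2, with ethyl, now stands alone as the strongest of the four, with the methyl, pentyl and tert-butyl compounds all within the scatter of one another.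

Nothing shown here explains why ethyl stands apart from the other three groups. On these data alone, whether a propyl chain or a cyclopropyl group on this carbon would match the ethyl compound or fall back with the others remains open, and so does the effect of plain hydrogen there.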